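From pyridin-4-yl to pyridin-3-yl: working notes

The source may hold more compounds than are shown below. What is called first, only, known or untested is meant among the compounds shown, and "the series" means these compounds.

In a functional assay on Huh-7 cells (Homo sapiens) for inhibition, read by CCK-8 assay, with a stated time of 72 h (a higher number here means a weaker inhibitor of growth, a lower number a stronger inhibitor of growth), compound 1 (`C#Cc1cccc(Nc2ncnc3cc(OC)c(OCCCCCN/C(=N\C#N)Nc4ccncc4)cc23)c1`) gives 1.64 nM as its reading and compound 2 (`C#Cc1cccc(Nc2ncnc3cc(OC)c(OCCCCCCN/C(=N\C#N)Nc4ccncc4)cc23)c1`) gives 1.87 nM as its reading, so the two stand level within the scatter. Compound 3 (`C#Cc1cccc(Nc2ncnc3cc(OC)c(OCCCCCN/C(=N\C#N)Nc4cccnc4)cc23)c1`) carries pyridin-3-yl in place of pyridin-4-yl on an amine nitrogen and otherwise matches compound 1. For the measured compounds named here, no measured pair covers this change. A moderate step towards weaker growth inhibition, beyond the scatter, is expected. The estimated step is a 6.1-fold higher number from compound 1 to compound 3 (0.79 log units; beyond the scatter) as a working figure. For compound 3 the estimated value is 10 nM (range 2 nM to 100 nM).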

Compound 3, concentration for 50% growth inhibition: 62.9 nM
For compound 3 the middle estimate is 6.3-fold (0.80 log units) below the measured one, within the range that was stated.
By their numbers in this assay, from the lowest: compounds 1 and 2 (each within the scatter of the next); then compound 3.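

Putting pyridin-3-yl in place of pyridin-4-yl on the amine nitrogen gives a 38-fold higher number from compound 1 to compound 3 (1.58 log units; beyond the scatter) in this assay, a large loss of growth inhibition from a change that leaves the atoms the same. Compound 1 and compound 2 stand level despite their different chains, whereas this position proves sensitive to where the pyridine ring is attached. Nothing at hand explains the size of this step.

Going by these compounds, it remains open whether pyridin-2-yl or phenyl on the same amine nitrogen would read closer to compound 1 or compound 3. Also open, on these data alone, is whether the longer chain of compound 2 would carry the same loss with pyridin-3-yl.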